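The source may report more compounds than this note shows. Statements on the series, on what has been measured and on what is new or still open speak of the compounds shown alone.

Compound 1 `O=C(O)[C@@H]1CCCN1C(=O)CN(c1nc(Cl)nc2[nH]cnc12)C1CC1` — 7.29%
Compound 2 `O=C(CN(c1ncnc2c1ncn2C1CCCCO1)C1CC1)N[C@@H](CC(=O)OCc1ccccc1)C(=O)OCc1ccccc1` — 0.06%

In a functional assay on the whole organism (Tail, strain ICR) with Mus musculus as the target, in the tail flick test, with a stated time of 150 min, at a dose of 25 umol/kg by the oral route (a lower number here means a weaker effect, a higher number a stronger effect of the compound at the dose given), compound 1 gives 7.29%, and compound 2 gives 0.06%; the two numbers sit within the scatter of each other, so compound 1 stands apart from compound 2 only nominally. Compound 3 `CC(C)[C@H](NC(=O)CN(c1nc(Cl)nc2[nH]cnc12)C1CC1)C(=O)O` is not yet measured. It differs from compound 1 in one place: (1-carboxy-2-methylpropyl)amino in place of 2-carboxypyrrolidin-1-yl on a carbonyl carbon. With both measured numbers low and close, no step beyond the scatter is expected; the step of a number 0.7 percentage points higher from compound 1 to compound 3 (within the scatter) is an estimate of little change. Compound 3 is expected to give about 8%, with a range from 0% to 25%.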

Compound 3, a percentage reported as activity, at one dose (the size of the read-out at that dose, not a potency): 7.86%
The estimate for compound 3 lay 0.1 percentage points above the measured number, and the stated range covers the measured number.
By their numbers in this assay, from the lowest: compounds 2, 1 and 3 (each within the scatter of the next).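

In this assay, (1-carboxy-2-methylpropyl)amino in place of 2-carboxypyrrolidin-1-yl on a carbonyl carbon gives a number 0.6 percentage points higher from compound 1 to compound 3 (within the scatter). At this place, a group with no ring and one with a five-membered non-aromatic ring, both carrying a carboxy group, therefore cannot be told apart at the dose given. No measured evidence bears on why they read alike. On these data alone, it remains open whether a primary amine or a hydroxyl group in place of the carboxy group would move the read-out beyond the scatter.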